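A Saturated Ring Replaces a Chlorophenyl on an Amine

A few compounds are considered here, and "the series" means these few. Any claim that something is new, unique, unknown or untested is made for them only; others in the source may bear on it.

Three measured compounds share one core that carries an amide-linked aminophenyl group, and all were tested in a functional assay on NCI-H460 cells (Homo sapiens) for antiproliferative activity, read by CCK-8 assay, with a stated time of 72 h, tested at 2 uM; on this read-out higher numbers stand for a stronger effect at the one concentration tested and lower numbers for a weaker effect. Compound 1 `CC1CCN(c2nc(Cl)nc3c2ncn3Cc2ccc(/C=C/C(=O)Nc3ccccc3N)cc2)CC1` gives 8.24%. Compound 2 `Nc1ccccc1NC(=O)/C=C/c1ccc(Cn2cnc3c(Nc4cccc(Cl)c4)nc(Cl)nc32)cc1` gives 7.11%, the lowest of the three numbers, although the step of a number 1.1 percentage points lower from compound 1 to compound 2 (within the scatter) lies within the scatter. Compound 3 `Nc1ccccc1NC(=O)/C=C/c1ccc(COCNc2nc(Nc3cccc(Cl)c3)c3ncn(C4CCCC4)c3n2)cc1` differs from compound 2 in more than one place. Compound 3 gives 37.1%, a number that stands beyond the scatter above compound 2.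

Compound 4 `Nc1ccccc1NC(=O)/C=C/c1ccc(Cn2cnc3c(NC4CCCCC4)nc(Cl)nc32)cc1` has not yet been measured. It differs from compound 2 in one place: cyclohexyl in place of 3-chlorophenyl on a nitrogen on an aromatic ring. Among the compounds with values here, the only measured step touching this position, a number 1.1 percentage points lower from compound 1 to compound 2 (within the scatter), replaced 4-methylpiperidin-1-yl by (3-chlorophenyl)amino and stayed within the scatter. Putting a six-membered non-aromatic ring of carbon only back onto this nitrogen is therefore expected to give a step of a number 1.9 percentage points higher from compound 2 to compound 4 (within the scatter), nothing beyond the scatter. Compound 4 is estimated at 9%, with a range from 0% to 25%.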

Compound 4, a percentage reported as inhibition, at one concentration (the size of the read-out at that concentration, not a potency): 8.09%
Beside the measured number, compound 4's estimate is 0.9 percentage points above it; the range from low to high includes it.
By their numbers in this assay, from the lowest: compounds 2, 4 and 1 (each within the scatter of the next); then compound 3.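

In this assay, cyclohexyl in place of 3-chlorophenyl on a nitrogen on an aromatic ring gives a number 1 percentage points higher from compound 2 to compound 4 (within the scatter) and so shows that, on this read-out, a six-membered aromatic ring and a six-membered non-aromatic ring of carbon only cannot be told apart at this nitrogen. Cyclohexylamino in place of 4-methylpiperidin-1-yl on an aromatic carbon gives a number 0.2 percentage points lower from compound 1 to compound 4 (within the scatter) and so adds a third group at this carbon that cannot be separated from the other two. Nothing available explains why these groups read alike.

Going by these compounds, whether a chain on this nitrogen ending in an amine or a carboxylic acid would move the number remains open. Compound 3 differs from these compounds in more than one place, so its number cannot be tied to any single change.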